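Dihydropyridine series: aryl substituent and guinea-pig muscle potency

This account rests on a few compounds, and the source may have more. Where it says the series, first, only, none or still open, it means among the compounds named here.

Measured so far:
compound 1 `COC(=O)C1=C(C)N=C(C)/C(=C(\O)OC)C1c1ccccc1Cl` — 2.19 nM
compound 2 `COC(=O)C1=C(C)N=C(C)/C(=C(\O)OC)C1c1ccc(F)cc1` — 129 nM
compound 3 `COC(=O)C1=C(C)N=C(C)/C(=C(\O)OC)C1c1ccc(C#N)cc1` — 3470 nM

In a functional assay (muscle tissue) with Cavia porcellus as the target (on this read-out higher numbers stand for an effect only at larger amounts of compound and lower numbers for an effect already at smaller amounts), compound 3 stands highest of the three, with compound 2 nearest and compound 1 furthest. Compound 4 `COC(=O)C1=C(C)N=C(C)/C(=C(\O)OC)C1c1cccc(Br)c1` differs from compound 3 as follows: 3-bromophenyl in place of 4-cyanophenyl on a saturated ring carbon. Among the compounds with values here, two measured steps bear on this change, both arriving at the 4-cyanophenyl: a 1600-fold higher number from compound 1 to compound 3 (3.20 log units; beyond the scatter) and a 27-fold higher number from compound 2 to compound 3 (1.43 log units; beyond the scatter). Removing the nitrile, as here, reverses those steps. Within the data shown here, no compound carries a 3-bromophenyl, so the size is uncertain, but a large step toward a lower number is expected, a 170-fold lower number from compound 3 to compound 4 (2.24 log units; beyond the scatter), placing compound 4 roughly between compound 2 and compound 1. Estimate for compound 4: 20 nM, range 2 nM to 200 nM.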

Compound 4, half-maximal effective concentration: 1.29 nM
Beside the measured number, compound 4's estimate is 16-fold (1.19 log units) above it, and the stated range ends above it.
By their numbers in this assay, from the lowest: compounds 4 and 1 (each within the scatter of the next); then compound 2; then compound 3.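

In this assay, the 3-bromophenyl gives a 2700-fold lower number from compound 3 to compound 4 (3.43 log units; beyond the scatter) and a 100-fold lower number from compound 2 to compound 4 (2.00 log units; beyond the scatter), so numbers this low on this saturated ring carbon do not depend on the 2-chlorophenyl. The two halogen-bearing groups stand level, with a 1.7-fold lower number from compound 1 to compound 4 (0.23 log units; within the scatter), while the 4-fluorophenyl, also halogen-bearing, stays far higher. No supporting data explain these steps.

The 3-bromophenyl and 4-cyanophenyl differ in both the group and its place on the phenyl ring, and these two changes cannot be separated here. On these data alone, whether an amine or a carboxylic acid on that phenyl ring would keep the number low remains open.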